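This account rests on a few compounds, and the source may have more. Where it says the series, first, only, none or still open, it means among the compounds named here.

Notes on the series. Compound 1 `CC(=O)c1ccc(NC(=O)Nc2cc(C)nc3ccccc23)cc1` has been run in an ADME assay on HEK293 cells (Homo sapiens) for cytotoxicity, with a stated time of 72 h (on this read-out higher numbers stand for an effect only at larger amounts of compound and lower numbers for an effect already at smaller amounts), and gives only a limit of the assay, > 25000 nM. Compound 2 `CSc1ccccc1NC(=O)Nc1cc(C)nc2ccccc12` likewise returns a limit in this assay, > 25000 nM. Compound 3 `Cc1cc(NC(=O)Nc2ccccc2C(N)=O)c2ccccc2n1` also stops at a limit in this assay, > 25000 nM. Among the measured compounds shown here, the one single-site change among the measured compounds, a step that the two limits leave unreadable from compound 2 to compound 3, has no readable size because of the limit of > 25000 nM in this assay, at which 3 of the 3 values shown sit. Compound 1 thus stands at the same limit as the other two measured compounds, and no order among the three can be drawn from these numbers.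

Compound 4 `Cc1cc(NC(=O)Nc2ccc(SC(F)(F)F)cc2)c2ccccc2n1` is still to be measured in this assay. It differs from compound 1 by (trifluoromethyl)sulfanyl in place of acetyl on an aromatic carbon. For the measured compounds named here, no measured step covers this exchange, and the only step that exists gives no size at all, so the expectation rests on the position of the measured compounds, which all sit at the limit due to the limit of > 25000 nM in this assay, at which 3 of the 3 values shown sit. Compound 4 is therefore expected to show no step beyond the scatter. The step that the limit leaves unreadable from compound 1 to compound 4 is expected to be flat, and the most likely outcome is that compound 4 is again reported only as a limit. The estimate for compound 4 is 40000 nM, with a range from 15000 nM to 100000 nM.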

Compound 4, half-maximal effective concentration: 13000 nM
Beside the measured number, compound 4's estimate is 3.1-fold (0.49 log units) above it; the whole stated range lies above it.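

Among the compounds shown here, compound 4 is the first to give a readable number in this assay rather than a limit, so a cytotoxic effect does come within the tested range once the group on an aromatic carbon of the six-membered ring of carbon only, para to a large group, is changed. From the compounds shown here alone, exchanging acetyl for (trifluoromethyl)sulfanyl at this position gives an at least 1.9-fold lower number from compound 1 to compound 4 (0.28 log units; that floor lies within the scatter); only a floor for the step is available, so its true size is unknown, and the floor alone does not establish a step beyond the scatter. The other step in the series cannot be read, because the remaining values stop at the same limit: the limit of > 25000 nM in this assay, at which 3 of the 4 values shown sit.

The compounds shown leave open how the read-out responds to other groups at this position, such as an amine, a carboxylic acid or a longer chain. They also leave open whether the sulfur or the three fluorines of the entering group go with the number seen for compound 4, since no single-site change separates the two.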